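From Nitro to Chloro: What to Expect of Compound 4

This account rests on a few compounds, and the source may have more. Where it says the series, first, only, none or still open, it means among the compounds named here.

Three compounds have been measured in a functional assay on K562 cells (Homo sapiens) for cytotoxicity, read by sulforhodamine B assay; a higher number here means a weaker inhibitor of growth, a lower number a stronger inhibitor of growth:

Compound 1 `CC1=CC[C@@H]([C@@](C)(O)CCCC(C)(C)NC(=S)N/N=C\c2ccccc2)CC1` gives 130 nM
Compound 2 `CC1=CC[C@@H]([C@@](C)(O)CCCC(C)(C)NC(=S)N/N=C\c2ccc(O)cc2)CC1` gives 600 nM
Compound 3 `CC1=CC[C@@H]([C@@](C)(O)CCCC(C)(C)NC(=S)N/N=C\c2ccccc2[N+](=O)[O-])CC1` gives 190 nM

Among these three numbers compound 3 stands second highest. Its nearest neighbour is compound 1, whose number lies within the scatter of it, while the step of a 3.2-fold lower number from compound 2 to compound 3 (0.50 log units; beyond the scatter) separates it from compound 2 by more than the scatter.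

Compound 4 `CC1=CC[C@@H]([C@@](C)(O)CCCC(C)(C)NC(=S)N/N=C\c2ccccc2Cl)CC1` differs from compound 3 in one place: chloro in place of nitro on an aromatic carbon. For the measured compounds named here, no measured compound carries a chloro group, so no step tells directly what this exchange does. Two steps give indirect guidance. The step of a 1.5-fold higher number from compound 1 to compound 3 (0.16 log units; within the scatter) shows that adding the nitro group to the unsubstituted ring barely changed the number, so removing it again should cost little. The step of a 4.6-fold higher number from compound 1 to compound 2 (0.66 log units; beyond the scatter) shows that a hydroxy group at another place on the ring weakened growth inhibition modestly, a reminder that a ring substituent can move the number, though that group and position are not the ones in question here.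

On balance, the step from compound 3 to compound 4 in this assay is expected to be a 1.1-fold lower number from compound 3 to compound 4 (0.05 log units; within the scatter), that is, nothing beyond the scatter. Compound 4 is therefore estimated at 170 nM, with a range from 70 nM to 420 nM.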

Compound 4, concentration for 50% growth inhibition: 150 nM
The estimate for compound 4 lay 1.1-fold (0.05 log units) above the measured number, within the range that was stated.
By their numbers in this assay, from the lowest: compounds 1, 4 and 3 (each within the scatter of the next); then compound 2.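

In this assay, the step of a 1.3-fold lower number from compound 3 to compound 4 (0.10 log units; within the scatter) shows that this place, ortho to a large group, accepts a single chlorine atom as readily as a nitro group of 3 heavy atoms, even though chloro brings 0 hydrogen-bond acceptors where nitro brings 2. The step of a 1.2-fold higher number from compound 1 to compound 4 (0.06 log units; within the scatter) adds that chloro, like nitro, leaves the number within the scatter of the compound with only hydrogen here, so three different occupants of this carbon now cannot be told apart in this assay, where earlier there were only two. For the compounds shown here, the step of a 4.0-fold lower number from compound 2 to compound 4 (0.60 log units; beyond the scatter) lies beyond the scatter, which leaves compound 2, with its 4-hydroxyphenyl group, as the only compound set apart from the others.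

Nothing measured here says why these groups behave alike. As far as these compounds go, it remains open whether an amine, a carboxylic acid or a longer chain on this aromatic carbon would also leave the number in place, and since compound 2 differs from compound 4 in both the group and where it sits, the two influences cannot be separated.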